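A fluoro for hydrogen swap on the phenyl of compound 2

The source may report more compounds than this note shows. Statements on the series, on what has been measured and on what is new or still open speak of the compounds shown alone.

Measured so far in a functional assay on LoVo cells (Homo sapiens) for inhibition, read by MTT assay, with a stated time of 24 h; a lower number here means a stronger inhibitor, a higher number a weaker inhibitor:
compound 1 `CC1(C)[C@H]2CC[C@]1(C)N(Cc1cn(-c3cccc(Cl)c3)nn1)C(=O)C2` gives 70 nM
compound 2 `CC1(C)[C@H]2CC[C@]1(C)N(Cc1cn(-c3ccccc3)nn1)C(=O)C2` gives 50 nM
compound 3 `CC1(C)[C@H]2CC[C@]1(C)N(Cc1cn(-c3ccccc3Br)nn1)C(=O)C2` gives 60 nM

Compound 2 gives the smallest number of the three, but the other two lie within the scatter of it: the step of a 1.4-fold lower number from compound 1 to compound 2 (0.15 log units; within the scatter) and the step of a 1.2-fold higher number from compound 2 to compound 3 (0.08 log units; within the scatter) are both small, so the three numbers are not told apart by this assay. Compound 4 `CC1(C)[C@H]2CC[C@]1(C)N(Cc1cn(-c3ccccc3F)nn1)C(=O)C2` differs from compound 2 by fluoro in place of hydrogen on an aromatic carbon.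

Within the data shown here, two measured steps bear on this change. The closest is the step of a 1.2-fold higher number from compound 2 to compound 3 (0.08 log units; within the scatter), a halogen entering in place of hydrogen on the same ring; the other halogen-for-hydrogen comparison, a 1.4-fold lower number from compound 1 to compound 2 (0.15 log units; within the scatter), is of the same small size. Neither step moves this assay beyond its scatter, so no change beyond the scatter is expected for compound 4. Compound 4 is therefore expected to give 55 nM, within a range from 30 nM to 110 nM. The step this estimate implies, a 1.1-fold higher number from compound 2 to compound 4 (0.04 log units; within the scatter), is expected to stay within the scatter.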

Compound 4, half-maximal inhibitory concentration: 40 nM
Beside the measured number, compound 4's estimate is 1.4-fold (0.14 log units) above it; the range from low to high includes it.
By their numbers in this assay, from the lowest: compounds 4, 2, 3 and 1 (each within the scatter of the next).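

In this assay, fluoro in place of hydrogen on an aromatic carbon, ortho to a large group, gives a 1.3-fold lower number from compound 2 to compound 4 (0.10 log units; within the scatter), so this change joins bromo at that place in not moving the number beyond the scatter. Fluoro in place of bromo gives a 1.5-fold lower number from compound 3 to compound 4 (0.18 log units; within the scatter), and 2-fluorophenyl in place of 3-chlorophenyl gives a 1.8-fold lower number from compound 1 to compound 4 (0.24 log units; within the scatter), so even these direct comparisons leave all four aryl groups on the aromatic nitrogen untold apart by this assay. Nothing at hand gives a reason for these small steps.

From the compounds shown here alone, whether the same holds for a non-halogen group on the ring, such as an amine, a methoxy group or a carboxylic acid, stays open. Going by these compounds, it is also open whether a longer chain in place of the phenyl would move the number beyond the scatter.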